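Chloro to Methoxy on the Pyrazole Aryl Ring

The source may hold more compounds than are shown below. What is called first, only, known or untested is meant among the compounds shown, and "the series" means these compounds.

Compound 1 `O=C(/C=C\Nc1ccc(F)cc1)c1cn(-c2ccccc2)nc1-c1ccc(Cl)cc1` is the reference point of this set. In an ADME assay on HaCaT cells (Homo sapiens) for antiproliferative activity, read by MTT assay, with a stated time of 48 h (on this read-out lower numbers stand for stronger inhibition and higher numbers for weaker inhibition), compound 1 gives > 50000 nM, which is a limit of the assay rather than a number (the limit of > 50000 nM in this assay, at which 1 of the 3 values shown sits). Compound 2 `O=C(/C=C\Nc1ccc(Cl)cc1)c1cn(-c2ccccc2)nc1-c1ccc(Cl)cc1` differs from it by the change fluoro in place of chloro on an aromatic carbon read in the opposite direction; in this assay compound 2 gives 23400 nM, and the step of an at least 2.1-fold lower number from compound 1 to compound 2 (0.32 log units; beyond the scatter) is beyond the scatter. Compound 3 `COc1ccc(N/C=C\C(=O)c2cn(-c3ccccc3)nc2-c2ccc(Cl)cc2)cc1` carries the change (methoxy in place of chloro on an aromatic carbon), and in this assay compound 3 gives 30800 nM; the step of a 1.3-fold higher number from compound 2 to compound 3 (0.12 log units; within the scatter) lies within the scatter, and the step of an at least 1.6-fold lower number from compound 1 to compound 3 (0.21 log units; that floor lies within the scatter) has a floor that also lies within the scatter.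

Compound 4 `COc1ccc(-c2nn(-c3ccccc3)cc2C(=O)/C=C\Nc2ccc(F)cc2)cc1` has not yet been measured in this assay. It differs from compound 1 by methoxy in place of chloro on an aromatic carbon. Among the measured compounds shown here, this is the same kind of change as the one from compound 2 to compound 3, but it sits on a different phenyl ring: one bond further out it reads 4-chlorophenyl to 4-methoxyphenyl, whereas for compound 3 it also reads (4-chlorophenyl)amino to (4-methoxyphenyl)amino. For the measured compounds named here, the one measured instance of the change, a 1.3-fold higher number from compound 2 to compound 3 (0.12 log units; within the scatter), gave a step within the scatter, so compound 4 is expected to show a step that the limit leaves unreadable from compound 1 to compound 4 from compound 1. Since compound 1 gives only a limit > 50000 nM, compound 4 is estimated at 60000 nM, with a range from 25000 nM to 150000 nM, and it is quite likely to be reported as a limit as well.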

Compound 4, half-maximal inhibitory concentration: 8910 nM
Estimate against measurement, compound 4: 6.7-fold (0.83 log units) above; the whole stated range lies above it.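

In this assay, methoxy in place of chloro on the 4-chlorophenyl ring of the core of compound 1 gave an at least 5.6-fold lower number from compound 1 to compound 4 (0.74 log units; beyond the scatter). Set beside the earlier instance, the change does not carry over as a single step from one core to the other: the same change on two cores in this assay, a 1.3-fold higher number (0.12 log units; within the scatter) from compound 2 to compound 3 and an at least 5.6-fold lower number (0.74 log units; beyond the scatter) from compound 1 to compound 4, at least 7.3-fold (0.86 log units) apart, beyond the scatter of two such steps Compound 1 gives > 50000 nM, which is a limit of the assay and not a number, so this step has only a floor, and the two instances, which sit on different phenyl rings, do not separate the effect of the ring that carries the change from that of the rest of the core, nor do they give a rule for any other core in the series.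

The compounds shown leave open whether a different group in the same place, such as an ethoxy group, a hydroxy group or a dimethylamino group, would give a step like that of methoxy on the core of compound 1. They also leave open what happens when methoxy stands on both phenyl rings at once, and whether the larger step would recur with a chloro group rather than a fluoro group on the other ring.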